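Microsomal stability of aryl variants on a shared core

The compounds below may be only part of what the source reports. "The series", "measured", "known", "first", "only" and "open" are said of these compounds alone.

Two members of the series have been measured in an ADME assay (liver) for metabolic stability, with Liver microsome (Canis lupus familiaris) as the target, read by LC-MS, using microsomes, with a stated time of 30 min, tested at 4 uM; a higher number here means that more of the compound is left, a lower number that less of the compound is left. Compound 1 `Cc1nc(N2CCN(C)CC2)c2nc(-c3cccc(Cl)c3)n(C3CCOCC3)c2n1` gives 45% and compound 2 `Cc1nc(N2CCN(C)CC2)c2nc(-c3ccccc3C(F)(F)F)n(C3CCOCC3)c2n1` gives 61%. Within the data shown here, the one step measured so far is a number 16 percentage points higher from compound 1 to compound 2 (beyond the scatter), and compound 2 therefore stands highest of the two numbers, with compound 1 the nearest at a value that lies beyond the scatter below it.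

Compound 3 `COc1cccc(-c2nc3c(N4CCN(C)CC4)nc(C)nc3n2C2CCOCC2)c1` has not yet been measured. It differs from compound 2 in one place: 3-methoxyphenyl in place of 2-(trifluoromethyl)phenyl on an aromatic carbon. Among the measured compounds shown here, no measured step covers this exchange directly; the only step that bears on it, a number 16 percentage points higher from compound 1 to compound 2 (beyond the scatter), shows that a change of the aryl group on this carbon can move this assay by a modest amount, and it ran toward the 2-(trifluoromethyl)phenyl group that compound 3 loses. A step back toward the level of compound 1 is therefore expected, namely a number 21 percentage points lower from compound 2 to compound 3 (beyond the scatter). Compound 3 is estimated to give 40%, within a range from 20% to 60%.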

Compound 3, percent of the compound remaining: 46%
Estimate against measurement, compound 3: 6 percentage points below; the range from low to high includes it.
By their numbers in this assay, from the lowest: compounds 1 and 3 (each within the scatter of the next); then compound 2.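

In this assay the 3-methoxyphenyl group, like the 3-chlorophenyl group, stands apart from the 2-(trifluoromethyl)phenyl group, with a number 15 percentage points lower from compound 2 to compound 3 (beyond the scatter) on this aromatic carbon. Methoxy in place of chloro gives a number 1 percentage points higher from compound 1 to compound 3 (within the scatter) and so does not separate the two groups, which leaves compound 2 as the only one of the three beyond the scatter from both others. No available finding accounts for these differences.

As far as these compounds go, whether the higher number of compound 2 goes with the trifluoromethyl group itself or with its place on the phenyl ring stays open, as the steps to compound 2 change both at once. From the compounds shown here alone, how a nitrile, an amine or a carboxylic acid on the phenyl ring would read in this assay also remains open.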